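Chain extension on the ring nitrogen of a thione core

A few compounds are considered here, and "the series" means these few. Any claim that something is new, unique, unknown or untested is made for them only; others in the source may bear on it.

Measured compounds:
Compound 1, `Cn1cnc2ncnn2c1=S` — 69%
Compound 2, `CCCn1cnc2ncnn2c1=S` — 49%

Of the compounds shown here, two sharing the same core have been tested in a functional assay on the whole organism for inhibition, with Rattus norvegicus as the target, at a dose of 30 mg/kg by the intraperitoneal route; on this read-out lower numbers stand for less inhibition and higher numbers for more inhibition at the one dose given (going by the name of the read-out). Compound 1 `Cn1cnc2ncnn2c1=S` gives 69%, and compound 2 `CCCn1cnc2ncnn2c1=S` gives 49%. Within the data shown here, the single measured step is a number 20 percentage points lower from compound 1 to compound 2 (beyond the scatter), so compound 2 stands lowest of the two numbers, with compound 1 the nearest point above it.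

Compound 3 `CCCCn1cnc2ncnn2c1=S` has not been measured. It differs from compound 2 by methyl in place of hydrogen on a saturated chain carbon, three bonds along the chain from an aromatic nitrogen. Among the measured compounds shown here, the only step that bears on this change is the one from compound 1 to compound 2, where the chain on the aromatic nitrogen grew by two carbons and the read-out fell by a modest amount beyond the scatter. The change to compound 3 is a smaller extension of the same chain, so a smaller drop is expected, possibly at the edge of the scatter. The step from compound 2 to compound 3 is estimated at a number 12 percentage points lower from compound 2 to compound 3 (beyond the scatter). Compound 3 is therefore expected to give 37%, with a range from 20% to 55%.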

Compound 3, a percentage reported as inhibition, in the whole organism at one dose (the size of the read-out at that dose, not a potency): 23%
Compound 3: the middle estimate sits 14 percentage points above what was measured; measured number inside the range.
By their numbers in this assay, from the lowest: compound 3; then compound 2; then compound 1.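

In this assay, methyl in place of hydrogen three bonds along the chain from an aromatic nitrogen, which turns propyl into butyl, gives a number 26 percentage points lower from compound 2 to compound 3 (beyond the scatter) and so shows that this single further carbon at this position is enough to move the number beyond the scatter. Across the whole series the change is a number 46 percentage points lower from compound 1 to compound 3 (beyond the scatter) and the earlier modest step now belongs to a single order of methyl, then propyl, then butyl, with no compound shown going against it and compound 3 giving the least inhibition of the three at this dose. Nothing available explains why inhibition falls as the chain grows.

The compounds shown leave open whether a longer chain such as pentyl or hexyl would lower the number further, and whether a branched chain such as isopropyl would follow the same order as the straight chains. They also leave open whether a hydroxyl, an amine or a carboxylic acid at the end of the butyl chain would keep or reverse this fall.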